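Benzoxazolone propanoic acids: lipophilicity notes, compound 3 to 4

The source may report more compounds than this note shows. Statements on the series, on what has been measured and on what is new or still open speak of the compounds shown alone.

Measured so far:
compound 1 `CCc1cc2oc(=O)n(CCC(=O)O)c2cc1Cl` — 1.94
compound 2 `COc1cc2oc(=O)n(CCC(=O)O)c2cc1Cl` — "not determined" (no result reported)
compound 3 `Cc1ccc([C@@H](C)Oc2cc3oc(=O)n(CCC(=O)O)c3cc2Cl)nc1` — 2.02

In a physicochemical assay for lipophilicity, read by HPLC, at pH 7.4 (on this read-out lower numbers stand for lower lipophilicity and higher numbers for higher lipophilicity), compound 3 gives 2.02. Among the compounds with values here, only one other number stands in the set: in this assay compound 1 gives 1.94, and the two values lie within the usual scatter of each other, so no order between compound 1 and compound 3 can be read from them. Compound 2 carries no number in this assay, so compound 3 is compared against a single measured neighbour.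

The next compound, compound 4 `C[C@@H](Oc1cc2oc(=O)n(CCC(=O)O)c2cc1Cl)c1ncco1`, differs from compound 3 in one place: 1,3-oxazol-2-yl in place of 5-methylpyridin-2-yl on a saturated chain carbon bound to an oxygen on an aromatic ring and a saturated chain carbon. Within the data shown here, no measured pair in the set shows this kind of exchange, so the size of the step is not anchored by data. The step from compound 3 to compound 4 in this assay is expected to be downward and beyond the scatter, a number 0.72 log units lower from compound 3 to compound 4 (beyond the scatter). For compound 4 in this assay the expected value is 1.3, with a range from 0.9 to 1.8.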

Compound 4, distribution coefficient: 1.11
The estimate for compound 4 lay 0.19 log units above the measured number, and the stated range covers the measured number.
By their numbers in this assay, from the lowest: compound 4; then compounds 1 and 3 (each within the scatter of the next).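

In this assay, within the data shown here, 1,3-oxazol-2-yl in place of 5-methylpyridin-2-yl on a saturated chain carbon bound to an oxygen on an aromatic ring and a saturated chain carbon gives the first step in the set beyond the scatter, a number 0.91 log units lower from compound 3 to compound 4 (beyond the scatter). A larger group on the aromatic carbon does not by itself set the number: compound 3 stands within the scatter of compound 1, whereas the group of 8 heavy atoms in place of the group of 2 heavy atoms gives a number 0.83 log units lower from compound 1 to compound 4 (beyond the scatter). Nothing measured here accounts for the size of these steps.

On these data alone, with a single exchange at this carbon, it remains open whether the step belongs to 1,3-oxazol-2-yl alone or extends to other five-membered aromatic rings. Where a phenyl or a 1,3-thiazol-2-yl group at the same place would fall also remains open.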